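The source may report more compounds than this note shows. Statements on the series, on what has been measured and on what is new or still open speak of the compounds shown alone.

Measured so far:
- compound 1 `CN1[C@@H]2c3[nH]c4ccccc4c3C[C@H]1[C@H](C#N)N1[C@@H](CNC(=O)c3cccc(C(F)(F)F)c3)c3[nH]c4ccccc4c3C[C@@H]21`: 870 nM
- compound 2 `CN1[C@@H]2c3[nH]c4ccccc4c3C[C@H]1[C@H](C#N)N1[C@@H](CNC(=O)c3cc4ccccc4[nH]3)c3[nH]c4ccccc4c3C[C@@H]21`: 1690 nM

Both numbers come from a functional assay on BGC-823 cells (Homo sapiens) for cytotoxicity, read by MTT assay, with a stated time of 72 h; a lower number here means a stronger inhibitor, a higher number a weaker inhibitor. Compound 1 has the smaller of the two, but the step of a 1.9-fold higher number from compound 1 to compound 2 (0.29 log units; within the scatter) is within the scatter of repeated measurements, so the two compounds cannot be separated on these data.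

The next compound is compound 3 `COc1ccc(/C=C/C(=O)NC[C@H]2c3[nH]c4ccccc4c3C[C@H]3[C@H]4c5[nH]c6ccccc6c5C[C@@H]([C@H](C#N)N23)N4C)cc1`, which differs from compound 1 in one place: 2-(4-methoxyphenyl)ethenyl in place of 3-(trifluoromethyl)phenyl on a carbonyl carbon. Among the compounds with values here, the only measured step on this carbonyl carbon, a 1.9-fold higher number from compound 1 to compound 2 (0.29 log units; within the scatter), exchanged the same leaving group for a different ring and produced no shift beyond the scatter. Within the data shown here, the group entering in compound 3 carries a double bond outside aromatic rings and one hydrogen-bond acceptor, and nothing among the measured compounds speaks directly to that kind of change. With one comparable step showing no real movement, the expectation for compound 3 is a step of a 1.1-fold higher number from compound 1 to compound 3 (0.06 log units; within the scatter), that is, no change beyond the scatter. The estimate for compound 3 in this assay is therefore 1000 nM, with a range from 350 nM to 3000 nM.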

Compound 3, half-maximal inhibitory concentration: 5450 nM
Beside the measured number, compound 3's estimate is 5.5-fold (0.74 log units) below it, outside the stated range (above it).
By their numbers in this assay, from the lowest: compounds 1 and 2 (each within the scatter of the next); then compound 3.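

In this assay, the group on this carbonyl carbon now shows a real effect on the number: 2-(4-methoxyphenyl)ethenyl in place of 3-(trifluoromethyl)phenyl gives a 6.3-fold higher number from compound 1 to compound 3 (0.80 log units; beyond the scatter) and, in place of 1H-indol-2-yl, gives a 3.2-fold higher number from compound 2 to compound 3 (0.51 log units; beyond the scatter). Within the data shown here, the one earlier step at this place stayed within the scatter and could have suggested that the group may be exchanged freely, but these two steps show that not every group is tolerated equally, though both are only modest in size. The entering and leaving groups of the step from compound 1 have the same count of heavy atoms and each holds one six-membered aromatic ring of carbon only, so those counts do not separate them, and nothing available here accounts for the weaker number of compound 3.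

The entering group brings a double bond outside aromatic rings and a methoxy group together, so the compounds shown cannot tell which of the two goes with the step. A 2-phenylethenyl group, without the methoxy, and a 2-(4-methoxyphenyl)ethyl group, without the double bond, on this carbonyl carbon would pull those two features apart.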